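A few compounds are considered here, and "the series" means these few. Any claim that something is new, unique, unknown or untested is made for them only; others in the source may bear on it.

Working notes on the series. Among the measured compounds shown here, compound 2 `CC(C)=CCCC1=CC[C@@H](C(=O)N(C)O)[C@H](c2ccccc2)C1` is the one member of the set with a number in an assay on isolated protein for inhibition of Apoptosis regulator Bcl-2 (Homo sapiens), read by fluorescence polarization, with stated times of 5 min and 10 min; a higher number here means a weaker inhibitor, a lower number a stronger inhibitor: compound 2 gives 2300 nM. Compound 1 `CC(C)=CCCC1=CC[C@H](C(=O)NCCC(=O)O)[C@@H](c2ccccc2)C1` returns only a limit of the assay, > 23000 nM. Compound 3 `CON(C)C(=O)[C@H]1CC2=C(CCCC2(C)C)C[C@@H]1c1ccccc1`, built on a different core, likewise returns only a limit, > 23000 nM. For the measured compounds named here, both of those sit at the limit of > 23000 nM in this assay, at which 2 of the 3 values shown sit, so compound 2 stands alone as the sole compound with a measured value, and no step between two numbers exists within the set.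

The next compound, compound 4 `CC(C)=CCCC1=CC[C@@H](C(=O)N(C)C)[C@H](c2ccccc2)C1`, is to be measured in this assay. It differs from compound 2 in one place: methyl in place of hydroxy on an amide-type nitrogen. The change removes the hydroxy from the amide-type nitrogen and puts a methyl there, so that the hydroxy(methyl)carbamoyl of compound 2 becomes the dimethylcarbamoyl of compound 4.

Going by the values given here, with no measured step of this kind available, the expectation rests on the structural change alone: the step from compound 2 to compound 4 is expected to be a loss beyond the scatter, a 6.1-fold higher number from compound 2 to compound 4 (0.78 log units; beyond the scatter). Compound 4 is accordingly estimated at 14000 nM, within 4000 nM to 40000 nM, with a real chance that only a limit is returned.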

Compound 4, inhibition constant: > 23000 nM
Compound 4 gave a limit, no number; the forecaster's own chance of this, stated with the estimate: 45%; middle value at least 1.6-fold (0.21 log units) from the limit.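

Among the compounds shown here, on the amide-type nitrogen of the shared core, methyl in place of hydroxy gives an at least 10-fold higher number from compound 2 to compound 4 (1.00 log units; beyond the scatter) in this assay, and this is the first step that can be read at all. With the rest of the structure unchanged, the hydroxy(methyl)carbamoyl of compound 2 retains a measurable value while the dimethylcarbamoyl of compound 4 does not, so the outcome in this assay depends on what sits at this one position, which the earlier values alone could not show. The real size of the step stays unknown, since compound 4 returns only a limit, and the series now sits mostly at that limit: the limit of > 23000 nM in this assay, at which 3 of the 4 values shown sit.

Going by these compounds, it remains open whether the loss follows from removing the hydroxy or from introducing the methyl, and a plain hydrogen or an ethyl on this nitrogen would help separate the two. On these data alone, it is also open how far the hydroxy(methyl)carbamoyl can be varied at all, for instance by a carboxylic acid in its place on the shared core, and whether any such change would give a value stronger than that of compound 2.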